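The source may hold more compounds than are shown below. What is called first, only, known or untested is meant among the compounds shown, and "the series" means these compounds.

Working notes on the three measured members of this series and one still to be measured. Compound 1 `COc1ccc(CN2C(=O)C(=O)c3cc(/C=C/C(=O)OC(C)(C)C)ccc32)cc1` gives 620 nM in a functional assay on HepG2 cells (Homo sapiens) for cytotoxicity, read by MTT assay, with a stated time of 48 h (a lower number here means a stronger inhibitor, a higher number a weaker inhibitor), the lowest of the two numbers in hand. Going by the values given here, compound 2 `CC(C)(C)OC(=O)/C=C/c1ccc2c(c1)C(=O)C(=O)N2Cc1ccc(Br)cc1` gives 2050 nM in this assay, and the step of a 3.3-fold higher number from compound 1 to compound 2 (0.52 log units; beyond the scatter) is the only measured step in the set. Compound 3 `COC(=O)/C=C/c1ccc2c(c1)N(Cc1ccc(OC)cc1)C(=O)C2=O` reaches only > 10000 nM in this assay, which is a limit of the assay rather than a number; (the limit of > 10000 nM in this assay, at which 1 of the 3 values shown sits). Compound 3 carries a methyl ester where compound 1 carries a tert-butyl ester, and the two values show the smaller ester at the limit and the larger one at the low end of the set.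

Compound 4 `CCOC(=O)/C=C/c1ccc2c(c1)C(=O)C(=O)N2Cc1ccc(OC)cc1` is the next member: ethyl in place of tert-butyl on an oxygen next to a carbonyl group. The bromo-for-methoxy step touches a different part of the molecule and does not bear on this change; what bears on it is the pair of values of compound 1 and compound 3, which runs from the low end to the limit. An ethyl ester stands between those two esters, so for compound 4 a step in the weaker direction is expected, a 6.5-fold higher number from compound 1 to compound 4 (0.81 log units; beyond the scatter). Compound 4 is therefore estimated at 4000 nM in this assay, within 1200 nM to 15000 nM, with a real chance that only a limit is returned.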

Compound 4, half-maximal inhibitory concentration: 90 nM
Beside the measured number, compound 4's estimate is 44-fold (1.65 log units) above it; measured number below the stated range.
By their numbers in this assay, from the lowest: compound 4; then compound 1; then compound 2. At a limit, above all of these: compound 3.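

In this assay, ethyl in place of tert-butyl on an oxygen next to a carbonyl group gives a 6.9-fold lower number from compound 1 to compound 4 (0.84 log units; beyond the scatter), so this position responds strongly to the ester group and the change runs in the stronger direction. Across the three esters the numbers do not follow the carbon count of the group: ethyl gives the lowest number, tert-butyl a higher one, and the methyl ester of compound 3 goes against any rule that larger or smaller is better. Compound 3 gives only a limit, not a number: the limit of > 10000 nM in this assay, at which 1 of the 4 values shown sits.

Still open, going by these compounds, is how an isopropyl ester, a longer chain on this oxygen, or the free carboxylic acid would read in this assay. Also open, on these data alone, is whether ethyl in place of tert-butyl gives a similar step alongside the bromo group of compound 2.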